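This account rests on a few compounds, and the source may have more. Where it says the series, first, only, none or still open, it means among the compounds named here.

In a functional assay on MCF7 cells (Homo sapiens) for antiproliferative activity, read by sulforhodamine B assay, with a stated time of 48 h (on this read-out lower numbers stand for stronger inhibition and higher numbers for weaker inhibition), three compounds that share one core have been measured so far. Compound 1 `Cc1ccc(NS(=O)(=O)c2ccc(N3CCNC3=O)cc2)cc1`, which carries methyl, gives 610 nM. Compound 3 `O=C1NCCN1c1ccc(S(=O)(=O)Nc2ccc(Br)cc2)cc1`, which carries bromo in that place, gives 240 nM, the lowest of the two true numbers available. Compound 2 `CCCCCCCc1ccc(NS(=O)(=O)c2ccc(N3CCNC3=O)cc2)cc1`, which carries heptyl there, gives > 1000 nM. That value is a limit of the assay and not a number.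

The next compound, compound 4 `CCCCCc1ccc(NS(=O)(=O)c2ccc(N3CCNC3=O)cc2)cc1`, has pentyl in place of bromo on an aromatic carbon, para to a large group: pentyl in place of bromo on an aromatic carbon.

For the measured compounds named here, three measured steps bear on this change. Swapping methyl for bromo gave a 2.5-fold lower number from compound 1 to compound 3 (0.41 log units; beyond the scatter), and swapping heptyl for bromo gave an at least 4.1-fold lower number from compound 2 to compound 3 (0.61 log units; beyond the scatter). Both are beyond the scatter, so in both cases the bromo compound has the lower number. Pentyl is a chain of the same kind as methyl and heptyl, so leaving bromo for pentyl should raise the number by a modest amount. The remaining step, an at least 1.6-fold higher number from compound 1 to compound 2 (0.21 log units; that floor lies within the scatter), has a floor within the scatter, so it does not show how far chain length alone moves the number.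

A rise beyond the scatter is therefore expected, estimated as a 3.3-fold higher number from compound 3 to compound 4 (0.52 log units; beyond the scatter). For compound 4, the estimated value is 800 nM, with an expected range from 300 nM to 2000 nM.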

Compound 4, half-maximal inhibitory concentration: > 1000 nM
Compound 4: only a limit was reported (the forecaster's own chance of this, stated with the estimate: 40%); middle value at least 1.2-fold (0.09 log units) from the limit.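

Putting pentyl in place of bromo on this aromatic carbon, para to a large group, gives an at least 4.1-fold higher number from compound 3 to compound 4 (0.61 log units; beyond the scatter), so in this assay a chain shorter than heptyl is already enough to lose the lower number seen with bromo. Measured against the methyl of compound 1, the same position gives an at least 1.6-fold higher number from compound 1 to compound 4 (0.21 log units; that floor lies within the scatter), and because that floor lies within the scatter, this step does not establish that lengthening the chain from methyl to pentyl raises the number. Compound 2 and compound 4 both stand at a limit of the assay rather than at a number, so the step between them cannot be read, because both sit at the same limit: the limit of > 1000 nM in this assay, at which 2 of the 4 values shown sit.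

The compounds shown leave open how the number moves between methyl and pentyl, a stretch that an ethyl, propyl or butyl chain in this place would fill in. They also leave open whether the lower number of compound 3 is particular to bromo or is shared by a chloro group, a methoxy group or an amine on the same aromatic carbon.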